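Adding a Chlorine Atom at Two Different Ring Positions

The compounds below may be only part of what the source reports. "The series", "measured", "known", "first", "only" and "open" are said of these compounds alone.

Of the compounds shown here, three have been tested in a functional assay on SJ-G2 cells (Homo sapiens) for inhibition, read by MTT assay, with a stated time of 72 h; on this read-out higher numbers stand for weaker inhibition of growth and lower numbers for stronger inhibition of growth. Compound 1 `COc1ccc(CNC(=O)/C(C#N)=C/c2ccco2)cc1` gives 31000 nM. Compound 2 `COc1ccc(CNC(=O)/C(C#N)=C/c2ccc(Cl)o2)cc1` carries one change, (chloro in place of hydrogen on an aromatic carbon), and gives 13000 nM, which is a 2.4-fold lower number from compound 1 to compound 2 (0.38 log units; beyond the scatter). Compound 3 `N#C/C(=C\c1ccccc1)C(=O)NCc1ccc(Cl)c(Cl)c1` gives 43000 nM; how its core differs from the core of compound 1 is not broken down here, but its number stands within the scatter of compound 1 and is the highest of the three.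

Compound 4 `N#C/C(=C\c1ccc(Cl)cc1)C(=O)NCc1ccc(Cl)c(Cl)c1`, not yet measured, differs from compound 3 by chloro in place of hydrogen on an aromatic carbon. This is the same kind of change as from compound 1 to compound 2, but the surroundings differ: in compound 2 the chlorine sits on a five-membered aromatic ring with one oxygen, next to the ring oxygen, whereas in compound 4 it sits on a six-membered aromatic ring of carbon only, para to a large group. For the measured compounds named here, because the one measured example of this change gave a 2.4-fold lower number from compound 1 to compound 2 (0.38 log units; beyond the scatter), a modest step of similar size is expected, namely a 2.0-fold lower number from compound 3 to compound 4 (0.29 log units; within the scatter). For compound 4 the estimate in this assay is 22000 nM, with a likely range from 8000 nM to 60000 nM.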

Compound 4, concentration for 50% growth inhibition: 30000 nM
The estimate for compound 4 lay 1.4-fold (0.13 log units) below the measured number; the range from low to high includes it.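

In this assay, going from phenyl to 4-chlorophenyl gives a 1.4-fold lower number from compound 3 to compound 4 (0.16 log units; within the scatter), so on this core the added chloro group leaves no change that can be told from the usual scatter of repeated measurements. The size of this step cannot be told apart from that of the earlier one on the core of compound 1: the same change on two cores in this assay, a 2.4-fold lower number (0.38 log units; beyond the scatter) from compound 1 to compound 2 and a 1.4-fold lower number (0.16 log units; within the scatter) from compound 3 to compound 4, 1.7-fold (0.22 log units) apart, within the scatter of two such steps. This shows that the two results are compatible with a similar small effect on both cores, but it does not show that the change reliably lowers the number, as only the earlier step lies beyond the scatter and two pairs cannot establish a rule for the series.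

The compounds shown leave open whether a different group in the same place, such as an amine or a carboxylic acid, would shift the number further than chloro does. They also leave open how the chloro change would behave at other ring positions or on other cores.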